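This account rests on a few compounds, and the source may have more. Where it says the series, first, only, none or still open, it means among the compounds named here.

The measured compounds in this set are:

- compound 1, `CCOc1cc(NC(=O)C2(NC(=O)c3ccc4c(C5CCCC5)c(-c5ncc(Cl)cn5)n(C)c4c3)CCC2)ccc1/C=C/C(=O)OCOP(=O)(O)OC(C)(C)C`, with 0.133 h
- compound 2, `CCCN(C)C(=O)COC(=O)/C=C/c1ccc(NC(=O)C2(NC(=O)c3ccc4c(C5CCCC5)c(-c5ncc(Cl)cn5)n(C)c4c3)CCC2)cc1OCC`, with 0.317 h

In an ADME assay (liver) for pharmacokinetics, with Liver microsome (Rattus norvegicus) as the target, using microsomes (on this read-out lower numbers stand for a shorter-lived compound and higher numbers for a longer-lived compound), compound 2 stands at the top of the two numbers available, with its half-life at 0.317 h. Compound 1 gives 0.133 h. Going by the values given here, the one step between them, a 2.4-fold higher number from compound 1 to compound 2 (0.38 log units; beyond the scatter), replaced a phosphorus-containing group with an amide-bearing chain on the saturated chain carbon bound to an oxygen next to the carbonyl.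

Compound 3, `CCOc1cc(NC(=O)C2(NC(=O)c3ccc4c(C5CCCC5)c(-c5ncc(Cl)cn5)n(C)c4c3)CCC2)ccc1/C=C/C(=O)OCC(=O)N1CCCC1`, differs from compound 2 only within that same amide-bearing chain: pyrrolidin-1-yl in place of methyl(propyl)amino on a carbonyl carbon. Among the compounds with values here, the single measured step does bear on the region, but it changed a far larger group than the one altered here, and no pair among the measured compounds compares one amine substituent with another on this carbonyl. The exchange of two five-heavy-atom amino groups of equal donor and acceptor count gives no footing in the data for a shift in either direction. The expected step is therefore a 1.0-fold higher number from compound 2 to compound 3 (0.00 log units; within the scatter), a step that lies within the scatter. Compound 3 is estimated at 0.32 h, with a range from 0.15 h to 0.65 h.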

Compound 3, half-life: 1.47 h
Compound 3: middle estimate off by 4.6-fold (0.66 log units), on the low side; the measured number lies above the stated range.
By their numbers in this assay, from the lowest: compound 1; then compound 2; then compound 3.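

In this assay, the amino group on this carbonyl carbon proves to matter in its own right: pyrrolidin-1-yl in place of methyl(propyl)amino gives a 4.6-fold higher number from compound 2 to compound 3 (0.67 log units; beyond the scatter) even though the two groups match in heavy atoms, hydrogen-bond donors and acceptors, and differ in the five-membered non-aromatic ring that pyrrolidin-1-yl carries. Going by these compounds alone, the earlier single step could show only that exchanging the phosphorus-containing group changed the half-life, whereas the same exchange now reaches an 11-fold higher number from compound 1 to compound 3 (1.04 log units; beyond the scatter) when the new chain ends in pyrrolidin-1-yl, so the size of that exchange depends on which amino group the amide holds. Nothing measured here accounts for the difference between these two amino groups.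

The compounds shown do not tell whether this result belongs to ring closure in general or to pyrrolidin-1-yl in particular, a question on which piperidin-1-yl, azetidin-1-yl or morpholin-4-yl on the same carbonyl carbon would bear. They also leave open where an open-chain group such as dimethylamino or diethylamino would fall relative to methyl(propyl)amino.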